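The source may report more compounds than this note shows. Statements on the series, on what has been measured and on what is new or still open speak of the compounds shown alone.

Working notes on the series. Three compounds share the same core and differ in the heteroaromatic ring system of the core and its substituent: compound 1 `CCCc1c(OCCCCOc2ccc(-c3nn[nH]n3)cc2)ccc2c(CC(C)(C)C)noc12`, compound 2 `CCCc1c(OCCCCOc2ccc(-c3nn[nH]n3)cc2)ccc2c1ccn2CC(C)(C)C` and compound 3 `CCCc1c(OCCCCOc2ccc(-c3nn[nH]n3)cc2)ccc2c1ncn2CC(C)(C)C`. In a functional assay for binding affinity to metabotropic glutamate receptor 2 (Homo sapiens), read by GTPgammaS binding, with a stated time of 1 h, at 30 degrees C (on this read-out higher numbers stand for an effect only at larger amounts of compound and lower numbers for an effect already at smaller amounts), compound 1 gives 788 nM, compound 2 gives 559 nM and compound 3 gives 6370 nM. Compound 2 holds the lowest of the three numbers; its gap to compound 1 is within the scatter, so the two cannot be ordered, while compound 3 stands apart from compound 2 beyond the scatter.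

The next compound, compound 4 `CCCc1c(OCCCCOc2ccc(-c3nn[nH]n3)cc2)ccc2c1ccn2CC1CCCCC1`, is not yet measured in this assay. It is compound 2 with one change: cyclohexyl in place of tert-butyl on a saturated chain carbon bound to an aromatic nitrogen. Going by the values given here, no pair already measured differs in this same place, so the size of the step has no direct precedent. The change keeps the ring system of compound 2 and replaces only the saturated group bound to the aromatic nitrogen, so the expected step from compound 2 to compound 4 in this assay, a 1.2-fold lower number from compound 2 to compound 4 (0.09 log units; within the scatter), is small and not expected to exceed the scatter. On that basis compound 4 is estimated at 450 nM, with a range from 150 nM to 1500 nM.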

Compound 4, half-maximal effective concentration: 228 nM
The estimate for compound 4 lay 2.0-fold (0.30 log units) above the measured number; the measured number falls inside the stated range.
By their numbers in this assay, from the lowest: compound 4; then compounds 2 and 1 (each within the scatter of the next); then compound 3.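

In this assay, the saturated group bound to the aromatic nitrogen proves to be a place where the number can move beyond the scatter while the ring system stays fixed: cyclohexyl in place of tert-butyl gives a 2.5-fold lower number from compound 2 to compound 4 (0.39 log units; beyond the scatter), a modest step and the first one read at this place in the series. It also shows that this place tolerates a larger group on this read-out, one with a six-membered non-aromatic ring of carbon only, and that the number goes down rather than up when this group enters. No supporting data accompany this step, so its cause remains unassigned.

A single step cannot show whether the lower number follows from the ring itself or from the greater number of carbon atoms, and cyclopentyl, phenyl or a longer open chain on the same saturated chain carbon would bear on that question. Also open, on these data alone, are whether cyclohexyl gives a step of similar size on the core of compound 1 or compound 3, and how a group carrying an amine or a hydroxyl would read at this place.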